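This account rests on a few compounds, and the source may have more. Where it says the series, first, only, none or still open, it means among the compounds named here.

Values in an ADME assay on MCF7-DOX cells (Homo sapiens) for cytotoxicity, read by MTT assay, with a stated time of 48 h; on this read-out lower numbers stand for stronger inhibition and higher numbers for weaker inhibition:
compound 1 `COc1cc(O)c(C(=O)/C=C/c2ccc(N3CCNCC3)cc2)c(OC)c1`: 67500 nM
compound 2 `COc1cc(OC)c(C(=O)/C=C/c2cccc(F)c2)c(O)c1CC=C(C)C`: 45400 nM
compound 3 `CCCCCc1c(OC)cc(OC)c(C(=O)/C=C/c2cccc(N3CCNCC3)c2)c1O`: > 100000 nM (a limit, not a number)

Within the data shown here, only two numbers are available in this assay: compound 2 gives 45400 nM and compound 1 gives 67500 nM, and these lie within the scatter of each other.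

The next compound is compound 4 `COc1cc(OC)c(C(=O)/C=C/c2cccc(N3CCNCC3)c2)c(O)c1CC=C(C)C`, which has piperazin-1-yl in place of fluoro on an aromatic carbon of compound 2, meta to a large group: piperazin-1-yl in place of fluoro on an aromatic carbon.

Among the measured compounds shown here, no step between measured compounds covers this change, so the expectation rests on the two other compounds carrying piperazin-1-yl. Compound 1 gives 67500 nM. Compound 3 gives > 100000 nM, which is a limit.

A small move towards a higher number is therefore expected, probably not beyond the scatter, and the estimated step is a 1.7-fold higher number from compound 2 to compound 4 (0.22 log units; within the scatter). For compound 4 the estimated value is 75000 nM, with an expected range of 30000 nM to 150000 nM.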

Compound 4, half-maximal inhibitory concentration: 99900 nM
For compound 4 the middle estimate is 1.3-fold (0.12 log units) below the measured one, within the range that was stated.
By their numbers in this assay, from the lowest: compounds 2, 1 and 4 (each within the scatter of the next, the first and the last beyond it). At a limit, above all of these: compound 3.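

In this assay, piperazin-1-yl in place of fluoro on an aromatic carbon, meta to a large group, gives a modest step: a 2.2-fold higher number from compound 2 to compound 4 (0.34 log units; beyond the scatter). The step rests on this single pair, and compound 1, which also carries piperazin-1-yl, stays within the scatter of compound 2, so no general effect of the group follows from these compounds. With 2-methylprop-1-en-1-yl in place of butyl on a saturated chain carbon bound to an aromatic carbon, the data give a number no higher from compound 3 to compound 4 (the limit leaves the size open), and the size of this step cannot be read. Compound 3 stands at a limit and has no number: the limit of > 100000 nM in this assay, at which 1 of the 4 values shown sits.

From the compounds shown here alone, whether the step belongs to piperazin-1-yl as a whole or to its free ring nitrogen stays open; a morpholine or an open-chain amine on the same aromatic carbon would separate the two. A methoxy group or a carboxylic acid there would show how far the read-out depends on the fluoro itself.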